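Propyl for cyclopropyl on the carbonyl: expected inhibition

The source may report more compounds than this note shows. Statements on the series, on what has been measured and on what is new or still open speak of the compounds shown alone.

Compound 2 `CC1=C(C(=O)C2CC2)C(c2ccco2)NC(=O)N1` gives 2% in an assay on membranes from CHO cells for displacement of a labelled ligand from adenosine receptor A1 (Homo sapiens), read by scintillation counting, with a stated time of 60 min, tested at 1 uM; a lower number here means less inhibition, a higher number more inhibition at the concentration tested (going by the name of the read-out). Compound 1 `CCOC(=O)C1=C(C)N(C)C(=O)NC1c1cccs1` gives 1% in this assay, and the two values lie within the scatter of one another, so neither compound stands apart. Compound 3 `CCCC(=O)C1=C(C)NC(=O)NC1c1ccco1` carries propyl in place of cyclopropyl on a carbonyl carbon. For the measured compounds named here, no measured pair shows the effect of exchanging these two groups, and both measured compounds show little displacement, so no step beyond the scatter is anticipated in either direction. Compound 3 is expected to give 3%, with a range of 0% to 15%. The expected step of a number 1 percentage points higher from compound 2 to compound 3 (within the scatter) is estimated to be negligible.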

Compound 3, a percentage reported as inhibition, at one concentration (the size of the read-out at that concentration, not a potency): 1%
For compound 3 the middle estimate is 2 percentage points above the measured one; the range from low to high includes it.
By their numbers in this assay, from the lowest: compounds 1, 3 and 2 (each within the scatter of the next).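

In this assay, for the compounds shown here, the step of a number 1 percentage points lower from compound 2 to compound 3 (within the scatter) is the first one-place comparison, and it shows that replacing cyclopropyl with propyl on this carbonyl carbon does not move the read-out beyond the scatter. Removing the ring therefore opens no measurable inhibition here, although with both compounds this low, the comparison says little about how the position would respond in a compound with higher inhibition. Nothing available explains the result.

From the compounds shown here alone, whether an amine, a carboxylic acid or a longer chain on this carbonyl carbon would give clear inhibition remains open. Also open, going by these compounds, is whether changes elsewhere on the shared core would raise inhibition enough to make this position informative.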